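The source may hold more compounds than are shown below. What is called first, only, known or untested is meant among the compounds shown, and "the series" means these compounds.

Working notes on the paw edema series.

Three compounds share one core and differ only in the group on the carbon with a double bond to nitrogen of the six-membered non-aromatic ring. Compound 1 `Cc1ccc(C2=NN(c3ccc(S(C)(=O)=O)cc3)C(=O)CC2)cc1` carries a methyl on the aromatic carbon of the pendant ring; in a functional assay on the whole organism (strain Wistar) for inhibition, with Rattus norvegicus as the target, read by paw edema, with stated times of 30 min and 3 h, at a dose of 0.05 mmol/kg by the oral route (a lower number here means less inhibition, a higher number more inhibition at the dose given (going by the name of the read-out)), compound 1 gives 46.7%. Compound 2 `COc1ccc(C2=NN(c3ccc(S(C)(=O)=O)cc3)C(=O)CC2)cc1` carries a methoxy in that position, and compound 2 gives 46.7%; the step of no change at the digits printed from compound 1 to compound 2 (within the scatter). Compound 3 `CS(=O)(=O)c1ccc(N2N=C(c3ccc(Br)cc3)CCC2=O)cc1` carries a bromo, and compound 3 gives 10%, the lowest of the three numbers. The drop a number 36.7 percentage points lower from compound 1 to compound 3 (beyond the scatter) and the drop a number 36.7 percentage points lower from compound 2 to compound 3 (beyond the scatter) are the two steps that bear on the next compound.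

Among the measured compounds shown here, compound 4 `CS(=O)(=O)c1ccc(N2N=C(c3ccc(Cl)c(Cl)c3)CCC2=O)cc1` is the one compound not yet measured. It differs from compound 3 in that (3,4-dichlorophenyl in place of 4-bromophenyl on a carbon with a double bond to nitrogen). For the measured compounds named here, both compounds carry halogen on the pendant ring, and compound 3 is the only halogen-bearing analogue with a number. Going by the values given here, no measured step exchanges one halogen for another, so the direction of the change cannot be read from the series; the two halogen-bearing compounds are taken to lie close together, because compound 3 gives 10%. The step from compound 3 to compound 4 is therefore expected to be small, a number 8 percentage points higher from compound 3 to compound 4 (within the scatter), with no clear direction beyond the scatter. For compound 4 the estimate is 18%, in the range 5% to 40%.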

Compound 4, a percentage reported as inhibition, in the whole organism at one dose (the size of the read-out at that dose, not a potency): 26.6%
Beside the measured number, compound 4's estimate is 8.6 percentage points below it; the measured number falls inside the stated range.
By their numbers in this assay, from the lowest: compound 3; then compound 4; then compounds 1 and 2 (each within the scatter of the next).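

Halogen on the pendant ring does not by itself set the low end of this assay: the exchange of 4-bromophenyl for 3,4-dichlorophenyl gives a number 16.6 percentage points higher from compound 3 to compound 4 (beyond the scatter), so the two halogen-bearing compounds now stand apart. The same group still falls short of the two non-halogen groups, with a number 20.1 percentage points lower from compound 1 to compound 4 (beyond the scatter) against 4-methylphenyl and a number 20.1 percentage points lower from compound 2 to compound 4 (beyond the scatter) against 4-methoxyphenyl, so this position gives three separate levels across the four compounds, with compound 4 in the middle and compounds 1 and 2 together at the top. No measurement in hand bears on the reason for these gaps.

The step from compound 3 to compound 4 changes the halogen and the number of halogen atoms together, so the compounds shown do not tell whether the higher number follows from chlorine in place of bromine or from the second chlorine. Also open, as far as these compounds go, is how the pendant ring would read with an amine, a carboxylic acid or a longer chain such as butyl in place of these groups.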